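The source may hold more compounds than are shown below. What is called first, only, known or untested is meant among the compounds shown, and "the series" means these compounds.

Working notes on the series. Compound 1 `COc1ccc2cc(-c3cn(-c4ccnc5cc(Cl)ccc45)nn3)ccc2c1` is the member without the ester chain. In an ADME assay on HepG2 cells (Homo sapiens) for cytotoxicity, read by MTT assay, with a stated time of 24 h (on this read-out lower numbers stand for higher toxicity in this test and higher numbers for lower toxicity in this test), compound 1 is reported only as a limit, > 2590000 nM. Compound 2 `COc1ccc(C(=O)OCCCc2cn(-c3ccnc4cc(Cl)ccc34)nn2)cc1` carries a methoxy group on its terminal ring, and in this assay compound 2 gives 347000 nM. Compound 3 `CCc1ccc(C(=O)OCCCc2cn(-c3ccnc4cc(Cl)ccc34)nn2)cc1` carries ethyl in that place. In this assay compound 3 is again reported only as a limit, > 2550000 nM. Among the compounds with values here, the single step available, an at least 7.3-fold higher number from compound 2 to compound 3 (0.86 log units; beyond the scatter), therefore rests on a limit at its upper end; its size is a lower bound. Compound 3 thus stands at the top of the numbers shown, with one further value also sitting at a limit of > 2550000 nM in this assay, at which 1 of the 3 values shown sits (the limit of > 2590000 nM in this assay, at which 1 of the 3 values shown sits), and no number for it is known.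

Compound 4 `Cc1ccc(C(=O)OCCCc2cn(-c3ccnc4cc(Cl)ccc34)nn2)cc1` differs from compound 3 by hydrogen in place of methyl on a saturated chain carbon bound to an aromatic carbon. Within the data shown here, no measured step concerns this change; the only step in hand, an at least 7.3-fold higher number from compound 2 to compound 3 (0.86 log units; beyond the scatter), swaps ethyl for methoxy and bears on it only loosely, as both compounds keep a small carbon group on the same ring carbon. With methyl kept in place of ethyl, a step of no more than the scatter is expected, an at least 1.2-fold lower number from compound 3 to compound 4 (0.10 log units; that floor lies within the scatter). Compound 4 is therefore estimated at 2000000 nM, between 500000 nM and 3000000 nM, with a fair chance that this assay again reports only a limit.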

Compound 4, half-maximal cytotoxic concentration: > 2460000 nM
Compound 4: only a limit was reported; the forecaster's own chance of this, stated with the estimate: 55%; at least 1.2-fold (0.08 log units) between middle value and limit.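

Methyl on the terminal ring keeps the gap that ethyl opened against methoxy: in this assay, the change gives an at least 7.0-fold higher number from compound 2 to compound 4 (0.85 log units; beyond the scatter). Among the ester-chain members shown, compound 2 is now the only one with a number, set against two alkyl members rather than one, and no listed compound among those three goes against this. The step from compound 3 to compound 4 cannot be read, so shortening ethyl to methyl yields no size of effect, and compound 4 gives only another limit: the limit of > 2460000 nM in this assay, at which 1 of the 4 values shown sits.

As far as these compounds go, how far compound 3 and compound 4 lie beyond their limits stays open, so ethyl and methyl cannot be placed in order, and any smaller difference between them would stay hidden in this read-out. Also open, from the compounds shown here alone, is whether the number of compound 2 belongs to methoxy alone or would appear again with other groups on the same ring carbon, such as an amine, a carboxylic acid or a longer chain like propyl.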